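The source may report more compounds than this note shows. Statements on the series, on what has been measured and on what is new or still open speak of the compounds shown alone.

Compounds measured in a functional assay for antagonist activity at Alpha-1A adrenergic receptor (Oryctolagus cuniculus); a lower number here means tighter binding, a higher number weaker binding:
compound 1 `CCOc1ccccc1N1CCN(CCCNc2ncccc2C(=O)N(C)C)CC1`, 0.501 nM
compound 2 `CN(C)C(=O)c1cccnc1NCCCN1CCN(c2ccccc2OCC2CC2)CC1`, 0.159 nM
compound 3 `CN(C)C(=O)c1cccnc1NCCCN1CCN(c2ccccc2-c2ccccc2)CC1`, 1.26 nM

Compound 3 stands at the highest number of the three in this assay; the steps that lead to it are a 2.5-fold higher number from compound 1 to compound 3 (0.40 log units; beyond the scatter) and a 7.9-fold higher number from compound 2 to compound 3 (0.90 log units; beyond the scatter), both beyond the scatter.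

Compound 4 `CN(C)C(=O)c1cccnc1NCCCN1CCN(c2ccccc2-c2ncco2)CC1` differs from compound 3 in one place: 1,3-oxazol-2-yl in place of phenyl on an aromatic carbon. Neither measured step bears on it directly: both replace the phenyl with an alkoxy group, not with another aromatic ring, and they show only that the phenyl gave the weaker number of the series. With an aromatic ring kept at the same place, no step beyond the scatter is expected for compound 4, so a 1.3-fold lower number from compound 3 to compound 4 (0.10 log units; within the scatter) is the estimate. In this assay compound 4 is expected to give 1 nM, within 0.3 nM to 3.2 nM.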

Compound 4, dissociation constant: 0.316 nM
The estimate for compound 4 lay 3.2-fold (0.50 log units) above the measured number; the range from low to high includes it.
By their numbers in this assay, from the lowest: compounds 2, 4 and 1 (each within the scatter of the next, the first and the last beyond it); then compound 3.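

In this assay, the ring at this place, on an aromatic carbon of a six-membered aromatic ring of carbon only, matters: 1,3-oxazol-2-yl in place of phenyl gives a 4.0-fold lower number from compound 3 to compound 4 (0.60 log units; beyond the scatter) without any alkoxy group. Among these compounds, the ether groups are therefore not the only groups that fit here, with a 2.0-fold higher number from compound 2 to compound 4 (0.30 log units; within the scatter) and a 1.6-fold lower number from compound 1 to compound 4 (0.20 log units; within the scatter) as the steps to the two ethers. No measurement available here explains the step from phenyl.

Ring size and hetero atoms change together in this step, so their shares remain unseparated. A pyridin-2-yl or 1,3-thiazol-2-yl ring would help to separate them.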